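This account rests on a few compounds, and the source may have more. Where it says the series, first, only, none or still open, it means among the compounds named here.

Measured so far:
compound 1, `CCCCCCCNc1cnc(C(=O)NCc2ccccc2)cn1` — in an ADME assay on HeLa cells (Homo sapiens) for cytotoxicity, read by microscopy, with a stated time of 6 days (a higher number here means that more compound is tolerated, a lower number that less compound is tolerated), compound 1 gives > 100000 nM
compound 2, `CCCCCNc1nccnc1C(=O)NCc1ccccc1` — in this assay compound 2 gives > 100000 nM

Both readings are limits of the assay, not numbers. For compound 1 the value > 100000 nM is such a limit. For compound 2 the value > 100000 nM is likewise a limit, so compound 2 stands at the ceiling of the scale together with compound 1, at the limit of > 100000 nM in this assay, at which 2 of the 2 values shown sit. Within the data shown here, no step between measured compounds that differ in a single place is available, so the series gives no measured step to lean on.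

Compound 3, `CCCCCCCNc1nccnc1C(=O)NCc1ccccc1`, is the next member. It differs from compound 2 by ethyl in place of hydrogen on a saturated chain carbon, five bonds along the chain from a nitrogen on an aromatic ring.

For this change, the step from compound 2 to compound 3 in this assay is expected to be a number no higher from compound 2 to compound 3 (the limit leaves the size open), which is to say none beyond the scatter, since both neighbours already sit at the limit. Compound 3 is therefore estimated at 100000 nM, with a range from 50000 nM to 200000 nM, and most likely the assay will again report only a limit.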

Compound 3, minimum cytotoxic concentration: > 100000 nM
Compound 3 gave a limit, no number (the forecaster's own chance of this, stated with the estimate: 85%); the middle value lies on the limit itself.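

No step can be read from compound 2 to compound 3, since both readings in this assay are limits and not numbers: the limit of > 100000 nM in this assay, at which 3 of the 3 values shown sit.

The compounds shown leave open where the minimum cytotoxic concentration of any of them lies, and whether ethyl in place of hydrogen changes it.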